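From Chloro to Hydrogen: What Compound 4 Might Show

A few compounds are considered here, and "the series" means these few. Any claim that something is new, unique, unknown or untested is made for them only; others in the source may bear on it.

Of the compounds shown here, three sharing one core have been measured in a functional assay on MCF7 cells (Homo sapiens) for inhibition, read by MTT assay, with a stated time of 72 h; on this read-out lower numbers stand for stronger inhibition and higher numbers for weaker inhibition. Compound 1 `COc1cc(-c2nc(SCc3cn(CC(=O)NC(=O)Nc4ccccn4)nn3)nc(Nc3ccc(C)cc3)c2C#N)cc(OC)c1OC` gives 21000 nM. Compound 2 `Cc1ccc(Nc2nc(SCc3cn(CC(=O)NC(=O)Nc4ccccn4)nn3)nc(-c3ccc(Br)cc3)c2C#N)cc1` gives 14400 nM, and compound 3 `Cc1ccc(Nc2nc(SCc3cn(CC(=O)NC(=O)Nc4ccccn4)nn3)nc(-c3ccc(Cl)cc3)c2C#N)cc1` gives 27000 nM. Compound 3 carries the highest of the three numbers, yet its nearest neighbour is compound 1 at a 1.3-fold higher number from compound 1 to compound 3 (0.11 log units; within the scatter), and the widest gap is a 1.9-fold higher number from compound 2 to compound 3 (0.27 log units; within the scatter); both lie within the scatter, so the three values cannot be told apart with confidence. The step of a 1.5-fold lower number from compound 1 to compound 2 (0.16 log units; within the scatter) is likewise within the scatter.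

Compound 4 `Cc1ccc(Nc2nc(SCc3cn(CC(=O)NC(=O)Nc4ccccn4)nn3)nc(-c3ccccc3)c2C#N)cc1` differs from compound 3 by hydrogen in place of chloro on an aromatic carbon. The step that bears most directly on this is the halogen exchange, a 1.9-fold higher number from compound 2 to compound 3 (0.27 log units; within the scatter), which stayed within the scatter; the broader replacements of the whole 3,4,5-trimethoxyphenyl group, a 1.5-fold lower number from compound 1 to compound 2 (0.16 log units; within the scatter) and a 1.3-fold higher number from compound 1 to compound 3 (0.11 log units; within the scatter), also stayed within it. Every change so far on this six-membered aromatic ring of carbon only has left the read-out essentially where it was, so removing the chloro is expected to do the same, with no step beyond the scatter in either direction, a 1.1-fold higher number from compound 3 to compound 4 (0.05 log units; within the scatter). The estimate for compound 4 is therefore 30000 nM, with a range from 12000 nM to 75000 nM.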

Compound 4, half-maximal inhibitory concentration: > 64000 nM
Compound 4 gave a limit, no number; the forecaster's own chance of this, stated with the estimate: 10%; at least 2.1-fold (0.32 log units) between middle value and limit.
By their numbers in this assay, from the lowest: compounds 2, 1 and 3 (each within the scatter of the next). At a limit, above all of these: compound 4.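

In this assay compound 4 gives > 64000 nM, which is a limit of the assay and not a number. Among the earlier compounds, no exchange on this six-membered aromatic ring of carbon only had moved the read-out beyond the scatter, but removing the group altogether does so in each comparison: an at least 2.3-fold higher number from compound 3 to compound 4 (0.37 log units; beyond the scatter), an at least 4.4-fold higher number from compound 2 to compound 4 (0.64 log units; beyond the scatter) and an at least 3.0-fold higher number from compound 1 to compound 4 (0.48 log units; beyond the scatter). Compounds 1, 2 and 3 cannot be told apart, so the three substituted rings shown behave alike here and only the unsubstituted phenyl of compound 4 stands apart, which makes the presence of a substituent at this place count for more than the choice among chloro, bromo and the 3,4,5-trimethoxyphenyl pattern.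

The compounds shown leave open whether a fluoro, a methyl, an amine or a carboxylic acid at this place would stay with compounds 1, 2 and 3 or fall with compound 4. They also leave open how large the loss really is and what lies behind it, since compound 4 sets only a lower bound on each step.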